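The compounds below may be only part of what the source reports. "The series", "measured", "known", "first", "only" and "open" are said of these compounds alone.

Among the measured compounds shown here, compound 2 (`O=C(CN1CCC(c2cccc[n+]2[O-])CC1)Nc1cc(Cl)cc(Cl)c1`) is one of two compounds measured here. In a functional assay on HEK293 cells for agonist activity at D(4) dopamine receptor (Homo sapiens), read by FLIPR (a higher number here means that more compound is needed for the effect, a lower number that less compound is needed), compound 2 gives 160 nM, the higher of the two numbers. Compound 1 (`Cc1cc(C(=O)NCN2CCC(c3cccc[n+]3[O-])CC2)ccc1F`) gives 50 nM in this assay, a number that lies beyond the scatter below that of compound 2. Compound 3 (`Cc1ccc(Cl)cc1NC(=O)CN1CCC(c2cccc[n+]2[O-])CC1`) has not yet been measured. It differs from compound 2 in a single place: 5-chloro-2-methylphenyl in place of 3,5-dichlorophenyl on an amide-type nitrogen. The amide linkage and the shared core are untouched. For the measured compounds named here, no measured pair shows the effect of such an exchange, so the direction of the step cannot be read from the data. Since both measured numbers sit within a modest span, the step expected in this assay is a 1.1-fold higher number from compound 2 to compound 3 (0.05 log units; within the scatter), not clearly beyond the scatter. Compound 3 is accordingly estimated at 180 nM, within a range from 60 nM to 550 nM.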

Compound 3, half-maximal effective concentration: 126 nM
Compound 3: the middle estimate sits 1.4-fold (0.15 log units) above what was measured, and the stated range covers the measured number.
By their numbers in this assay, from the lowest: compound 1; then compounds 3 and 2 (each within the scatter of the next).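

In this assay, among the compounds shown here, the change from 3,5-dichlorophenyl to 5-chloro-2-methylphenyl on the amide-type nitrogen gives the first reading at this position: a 1.3-fold lower number from compound 2 to compound 3 (0.10 log units; within the scatter). For this pair, then, the two aryl groups cannot be told apart in this assay, and the 3,5-dichlorophenyl group is not needed to keep the number within the scatter of compound 2. Nothing shown offers an explanation for this outcome.

The compounds shown leave open how far this tolerance extends, for instance to an unsubstituted phenyl, a 3,5-dimethylphenyl or a cyclohexyl on the same nitrogen. Compound 1 differs from compound 2 and compound 3 in more than one place, so its distance from them cannot be assigned to any single change.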